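Compound 3 against the limit of compound 2

The source may report more compounds than this note shows. Statements on the series, on what has been measured and on what is new or still open speak of the compounds shown alone.

Measured in a functional assay on HeLa cells (Homo sapiens) for inhibition; on this read-out higher numbers stand for weaker inhibition and lower numbers for stronger inhibition
compound 1 `Cc1cn(COCCO)c(=O)n(/C=C/C=O)c1=O` gives 20000 nM
compound 2 `CC(=O)/C=C/n1cc(C)c(=O)[nH]c1=O` gives > 100000 nM

In this assay compound 2 gives > 100000 nM, which is a limit of the assay and not a number. Going by the values given here, compound 1 gives 20000 nM, the only true number so far, but no single-place step connects the two compounds.

Compound 3 `Cc1cn(/C=C/C=N/O)c(=O)[nH]c1=O` keeps the frame of compound 2. An acetyl group gives way to a group of 3 heavy atoms (1 carbon, 1 nitrogen, 1 oxygen; no ring), on a double-bonded chain carbon bound to a double-bonded chain carbon (a group of 3 heavy atoms (1 carbon, 1 nitrogen, 1 oxygen; no ring) in place of a group of 3 heavy atoms (2 carbon, 1 oxygen; no ring), on a double-bonded chain carbon bound to a double-bonded chain carbon).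

Among the compounds with values here, no measured step sizes this change, so only a modest shift toward stronger inhibition is anticipated in this assay, and another limit reading remains quite possible. The estimated step is an at least 1.6-fold lower number from compound 2 to compound 3 (0.22 log units; that floor lies within the scatter). Compound 3 is expected at 60000 nM, with an estimated range of 20000 nM to 100000 nM.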

Compound 3, half-maximal inhibitory concentration: > 100000 nM
Compound 3: a limit, no number; the forecaster's own chance of this, stated with the estimate: 50%; middle value at least 1.6-fold (0.22 log units) away from the limit.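

In this assay compound 3 gives > 100000 nM as a limit of the assay and not a number. Compound 2 also stands at a limit, and no step from compound 2 to compound 3 can be read: the limit of > 100000 nM in this assay, at which 2 of the 3 values shown sit.

The compounds shown leave open whether replacing the acetyl group changes inhibition in this assay at all.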